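A few compounds are considered here, and "the series" means these few. Any claim that something is new, unique, unknown or untested is made for them only; others in the source may bear on it.

Compound 1 `CCNc1cc(-c2ccc(NC(=O)Nc3ccc(OC)cc3)cc2C(F)(F)F)ccn1` gives 5740 nM
Compound 2 `CCNc1cc(-c2ccc(NC(=O)Nc3cccc(Cl)c3)cc2F)ccn1` gives 6940 nM

Both values come from a functional assay on MCF7 cells (Homo sapiens) for cytotoxicity, read by MTT assay, with a stated time of 24 h (on this read-out higher numbers stand for weaker inhibition and lower numbers for stronger inhibition), and compound 2 lies within the scatter of compound 1, so the two values set no order. Within the data shown here, no measured step between compounds differing in one place is available. Compound 3 `CCNc1cc(-c2ccc(NC(=O)Nc3ccc(OC)cc3)cc2F)ccn1` has 4-methoxyphenyl in place of 3-chlorophenyl on an amide-type nitrogen of compound 2 (4-methoxyphenyl in place of 3-chlorophenyl on an amide-type nitrogen). The expectation in this assay rests on thin evidence. Compound 1 also carries 4-methoxyphenyl and gives 5740 nM, within the scatter of compound 2, although it differs from compound 3 elsewhere as well. The estimated 1.1-fold lower number from compound 2 to compound 3 (0.05 log units; within the scatter) is therefore expected to show no change beyond the scatter, with no direction favoured. The estimate for compound 3 is 6200 nM, with an expected range from 2900 nM to 13000 nM.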

Compound 3, half-maximal inhibitory concentration: 14100 nM
Compound 3: the middle estimate sits 2.3-fold (0.36 log units) below what was measured, and the stated range ends below it.
By their numbers in this assay, from the lowest: compounds 1 and 2 (each within the scatter of the next); then compound 3.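

In this assay, the aryl group on the amide-type nitrogen whose other neighbour is the carbonyl carbon now has a measurable effect: 4-methoxyphenyl in place of 3-chlorophenyl gives a 2.0-fold higher number from compound 2 to compound 3 (0.31 log units; beyond the scatter) and moves the number toward weaker inhibition. With 4-methoxyphenyl held constant, fluoro in place of trifluoromethyl on an aromatic carbon gives a 2.5-fold higher number from compound 1 to compound 3 (0.39 log units; beyond the scatter) in the same direction, so the series also responds at this second site, although both steps are modest. Nothing measured here accounts for either step.

The 4-methoxyphenyl and 3-chlorophenyl groups differ in both substituent and its place on the ring, so the first step cannot be assigned to either difference, and an unsubstituted phenyl would give a common reference. On the aromatic carbon, only fluoro and trifluoromethyl are compared, leaving hydrogen or nitrile at that site open.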